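Removing the propyl branch from a tetrazole-bearing side chain

This account rests on a few compounds, and the source may have more. Where it says the series, first, only, none or still open, it means among the compounds named here.

Compound 1 `CCCC(CCc1nnn[nH]1)Cc1cccc(OCc2ccc3ccccc3n2)c1`: 16 nM
Compound 2 `c1ccc2nc(COc3ccc(OCCCc4nnn[nH]4)cc3)ccc2c1`: 250 nM
Compound 3 `CCCC(CCc1nnn[nH]1)Cc1ccc(OCc2ccc3ccccc3n2)cc1`: 32 nM

Three compounds share a quinoline-methoxy aryl motif carrying a chain that ends in a tetrazole, and all three were tested in a functional assay (lung) for inhibition, with Cavia porcellus as the target; a higher number here means a weaker inhibitor, a lower number a stronger inhibitor. Compound 1 gives 16 nM, the lowest of the three numbers shown. Compound 3 gives 32 nM, and its separation from compound 1 falls within the usual scatter, so the two cannot be told apart. Compound 2 gives 250 nM, and here the separation from compound 1 lies beyond the scatter; compound 2, however, differs from compound 1 in more than one place, so no single change can be read from that pair.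

Compound 4 `c1cc(CCCCc2nnn[nH]2)cc(OCc2ccc3ccccc3n2)c1` has not yet been measured. It differs from compound 1 by one change: hydrogen in place of propyl on a saturated chain carbon bound to two saturated chain carbons. Among the measured compounds shown here, no measured pair isolates this particular change, so the expectation rests on the values of compound 1 and compound 2 alone. For the measured compounds named here, a modest weakening is expected, since the only compound without the propyl, compound 2, gives 250 nM, though it also differs elsewhere. The step of a 3.8-fold higher number from compound 1 to compound 4 (0.57 log units; beyond the scatter) is the estimated effect. Compound 4 is expected to give about 60 nM, with a range from 15 nM to 250 nM.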

Compound 4, half-maximal inhibitory concentration: 105 nM
Beside the measured number, compound 4's estimate is 1.8-fold (0.24 log units) below it; the range from low to high includes it.
By their numbers in this assay, from the lowest: compounds 1 and 3 (each within the scatter of the next); then compound 4; then compound 2.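

In this assay, among the compounds shown here, hydrogen in place of propyl on a saturated chain carbon bound to two saturated chain carbons gives a 6.6-fold higher number from compound 1 to compound 4 (0.82 log units; beyond the scatter) as the only change between the two structures. This pair is the first among the compounds shown to isolate the change, so the loss of the propyl at this position can now be read free of the other differences that compound 2 carries, and it is a weakening beyond the scatter. The data shown hold no evidence on what lies behind this step, so its size stands as an observation only.

What remains open is how the number depends on the group at this carbon: a methyl, an ethyl or a longer chain such as butyl could fall nearer to compound 1 or nearer to compound 4, and the compounds shown do not settle which. They also leave open whether hydrogen in place of propyl on compound 3 would bring a step of similar size.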